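Swapping the thiophene group on compound 2

The source may hold more compounds than are shown below. What is called first, only, known or untested is meant among the compounds shown, and "the series" means these compounds.

compound 1 `Cc1ccsc1-c1cc(-c2ccco2)cc(-c2ccccc2Cl)n1`: 14200 nM
compound 2 `Cc1ccsc1-c1cc(-c2ccco2)cc(-c2ccc(Cl)cc2)n1`: 890 nM
compound 3 `Cc1ccsc1-c1cc(-c2ccoc2)cc(-c2ccc(Cl)cc2)n1`: 20300 nM

In a functional assay on MCF7 cells (Homo sapiens) for cytotoxicity, read by ELISA, with a stated time of 4 days (a lower number here means a stronger inhibitor, a higher number a weaker inhibitor), compound 2 gives 890 nM, the lowest of the three numbers. Compound 4 `Clc1ccc(-c2cc(-c3ccco3)cc(-c3ccc(Cl)s3)n2)cc1` differs from it in one place: 5-chlorothiophen-2-yl in place of 3-methylthiophen-2-yl on an aromatic carbon. This is 5-chlorothiophen-2-yl in place of 3-methylthiophen-2-yl, next to the ring nitrogen. Among the compounds with values here, no measured step touches this group. The two measured steps elsewhere on the shared core are both large: a 16-fold lower number from compound 1 to compound 2 (1.20 log units; beyond the scatter) and a 23-fold higher number from compound 2 to compound 3 (1.36 log units; beyond the scatter). Within the data shown here, they show only that single changes on this core can matter. Compound 2 at 890 nM already holds the lowest number, so a moderate step towards a higher number is expected, with wide uncertainty. The expected change is a 2.8-fold higher number from compound 2 to compound 4 (0.45 log units; beyond the scatter). For compound 4 the estimated value is 2500 nM, with an expected range of 400 nM to 15000 nM.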

Compound 4, half-maximal inhibitory concentration: 1520 nM
Compound 4: middle estimate off by 1.6-fold (0.22 log units), on the high side; the measured number falls inside the stated range.
By their numbers in this assay, from the lowest: compounds 2 and 4 (each within the scatter of the next); then compounds 1 and 3 (each within the scatter of the next).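

At the position next to the ring nitrogen, 5-chlorothiophen-2-yl in place of 3-methylthiophen-2-yl gives a 1.7-fold higher number from compound 2 to compound 4 (0.23 log units; within the scatter) in this assay, so compound 2 and compound 4 cannot be told apart here. This first measured change at this position is therefore far smaller than the large steps seen elsewhere on the shared core. Nothing available explains this result.

The swap changes both the thiophene's substituent and its place, and the two cannot be separated. As far as these compounds go, how an amine or a longer alkyl chain would behave at this position remains open.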